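Pyrrolidin-1-yl in place of cyclobutyl on a carbonyl carbon

The compounds below may be only part of what the source reports. "The series", "measured", "known", "first", "only" and "open" are said of these compounds alone.

Among the measured compounds shown here, in a physicochemical assay for solubility, read by HPLC, in phosphate buffer, measured as kinetic solubility, at pH 7.4 (on this read-out lower numbers stand for lower solubility and higher numbers for higher solubility), three compounds have numbers so far. Compound 1 (`CCC(=O)c1cc(-c2ccc(Cl)cc2)n(-c2ccc(S(C)(=O)=O)cc2)c1C`) gives 4800 nM. Compound 2 (`CCCC(=O)c1cc(-c2ccc(S(N)(=O)=O)cc2)n(-c2ccc(Cl)cc2)n1`) gives 25800 nM. Compound 3 (`NS(=O)(=O)c1ccc(-c2cc(C(=O)C3CCC3)nn2-c2ccc(Cl)cc2)cc1`) gives 17200 nM, which is within the scatter of compound 2 and higher than compound 1 by more than the scatter.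

Compound 4 (`NS(=O)(=O)c1ccc(-c2cc(C(=O)N3CCCC3)nn2-c2ccc(Cl)cc2)cc1`) has not yet been measured in this assay. It carries pyrrolidin-1-yl in place of cyclobutyl on a carbonyl carbon. For the measured compounds named here, one measured step bears on this place: a 1.5-fold lower number from compound 2 to compound 3 (0.18 log units; within the scatter). That exchange of propyl for cyclobutyl involves carbon-only groups, whereas the entering group here contains a nitrogen, so the step is only a loose guide to size. Going by the values given here, no measured compound carries pyrrolidin-1-yl, which leaves the direction weakly supported. No step beyond the scatter is therefore expected in this assay, with only a slight lean towards a higher number. The expected change is a 1.4-fold higher number from compound 3 to compound 4 (0.14 log units; within the scatter). Compound 4 is estimated at 24000 nM, with an expected range of 10000 nM to 55000 nM.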

Compound 4, solubility: 57900 nM
The estimate for compound 4 lay 2.4-fold (0.38 log units) below the measured number, and the stated range ends below it.
By their numbers in this assay, from the lowest: compound 1; then compounds 3 and 2 (each within the scatter of the next); then compound 4.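

In this assay the place on the carbonyl carbon proves sensitive to the group it carries: pyrrolidin-1-yl in place of cyclobutyl gives a 3.4-fold higher number from compound 3 to compound 4 (0.53 log units; beyond the scatter) and pyrrolidin-1-yl in place of propyl gives a 2.2-fold higher number from compound 2 to compound 4 (0.35 log units; beyond the scatter) so the same entering group clears the scatter against both carbon-only groups. Among the compounds shown here, the only earlier step at this place, between the carbon-only groups propyl and cyclobutyl, stayed within the scatter (a 1.5-fold lower number from compound 2 to compound 3 (0.18 log units; within the scatter)), and these new steps are the first at this place to involve a group containing nitrogen. No measurement at hand accounts for the higher number of compound 4.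

For the compounds shown here, with pyrrolidin-1-yl as the only nitrogen-bearing group at this place, the step cannot be divided between the ring nitrogen and the change from a four-membered to a five-membered ring. On these data alone, open-chain dimethylamino, piperidin-1-yl or morpholin-4-yl on the same carbonyl carbon, or cyclopentyl as the all-carbon five-membered ring, would bear on that question, and it also remains open how far the step holds with other groups on the shared core.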